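Bromo to methyl on the pyridine-bearing side chain

This account rests on a few compounds, and the source may have more. Where it says the series, first, only, none or still open, it means among the compounds named here.

Three compounds of the shared core have numbers in an assay on CHO-K1 cells for displacement of a labelled ligand from Neuronal acetylcholine receptor; alpha4/beta2 (Homo sapiens), read by scintillation counting; a higher number here means a weaker inhibitor, a lower number a stronger inhibitor. Compound 1 `Clc1cc(OC[C@@H]2C[C@H]3C[C@H]3N2)cnc1Cl` gives 149 nM, compound 2 `Brc1ccc(OC[C@@H]2C[C@H]3C[C@H]3N2)cn1` gives 46.5 nM, and compound 3 `Clc1cncc(OC[C@@H]2CC[C@H]3C[C@H]3N2)c1` gives 31.3 nM. Compound 2 holds the second highest of the three numbers; its nearest neighbour is compound 3, whose number is lower by an amount within the scatter, so no order between compound 2 and compound 3 can be read. Compound 1 stands furthest from compound 2, with a higher number beyond the scatter.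

The step under consideration goes from compound 2 to compound 4 `Cc1ccc(OC[C@@H]2C[C@H]3C[C@H]3N2)cn1`, which is yet to be measured in this assay . The change is methyl in place of bromo on an aromatic carbon, methyl entering where bromo leaves, next to the ring nitrogen and para to a group of 8 heavy atoms. For the measured compounds named here, no measured pair in this set differs in exactly this way, so the size of the step cannot be taken from a neighbouring comparison.

The expectation is a modest rise in the number, of roughly the size of the gap from compound 2 to compound 1, though possibly within the scatter: an expected step of a 2.6-fold higher number from compound 2 to compound 4 (0.41 log units; beyond the scatter). Compound 4 is estimated at 120 nM in this assay , with a range from 40 nM to 400 nM.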

Compound 4, inhibition constant: 26.2 nM
For compound 4 the middle estimate is 4.6-fold (0.66 log units) above the measured one, and the stated range ends above it.
By their numbers in this assay, from the lowest: compounds 4, 3 and 2 (each within the scatter of the next); then compound 1.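

In this assay, for the compounds shown here, methyl in place of bromo on an aromatic carbon, next to the ring nitrogen and para to a group of 8 heavy atoms, gives a 1.8-fold lower number from compound 2 to compound 4 (0.25 log units; within the scatter), the first step that changes this position alone. Bromo and methyl cannot be told apart here, so bromo is not required at this position for a number of this size, and a carbon group can stand in place of the halogen without a step beyond the scatter. Nothing available accounts for the two groups reading alike, and no measurement of any property of compound 2 or compound 4 bears on this result.

On these data alone, whether this position accepts groups of a different kind remains open: an amine, a methoxy group, a carboxylic acid or a longer chain such as propyl could show how much room the tolerance seen with methyl really has. Also open, as far as these compounds go, is whether methyl in place of bromo gives a step of similar size on the core of compound 3, or on a ring that also carries the second chloro of compound 1.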